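The source may hold more compounds than are shown below. What is called first, only, known or untested is meant among the compounds shown, and "the series" means these compounds.

Measured in a functional assay on SW-620 cells (Homo sapiens) for antiproliferative activity, read by MTT assay, with a stated time of 72 h; on this read-out lower numbers stand for stronger inhibition and higher numbers for weaker inhibition:
- Compound 1 `COc1ccccc1-c1cn(C[C@H](O)[C@H]2OC(=O)C(OCc3ccccc3)=C2OCc2ccccc2)nn1`: > 100000 nM (a limit of the assay, not a number)
- Compound 2 `O=C1O[C@H]([C@@H](O)Cn2cc(CNS(=O)(=O)c3ccc(F)cc3)nn2)C(OCc2ccccc2)=C1OCc1ccccc1`: 41100 nM
- Compound 3 `Cc1ccc(S(=O)(=O)NCc2cn(C[C@H](O)[C@H]3OC(=O)C(OCc4ccccc4)=C3OCc3ccccc3)nn2)cc1`: 45800 nM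

The two numbers show no separation: a 1.1-fold higher number from compound 2 to compound 3 (0.05 log units; within the scatter). Compound 3 therefore stands level with compound 2.

Compound 4 `O=C1O[C@H]([C@@H](O)Cn2ccnn2)C(OCc2ccccc2)=C1OCc1ccccc1` differs as follows: hydrogen in place of (((4-methylphenyl)sulfonyl)amino)methyl on an aromatic carbon.

Changes on this same carbon gave only modest measured steps, an at least 2.4-fold lower number from compound 1 to compound 2 (0.38 log units; beyond the scatter) and an at least 2.1-fold lower number from compound 1 to compound 3 (0.33 log units; beyond the scatter), and both rest on a limit. Within the data shown here, no measured step removes the group outright. A small step toward a higher number in this assay, probably within the scatter, is therefore expected. The expected step is a 1.3-fold higher number from compound 3 to compound 4 (0.12 log units; within the scatter).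

For compound 4 the estimate is 60000 nM, with an expected range of 15000 nM to 150000 nM.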

Compound 4, half-maximal inhibitory concentration: > 100000 nM
Compound 4: a limit, no number (the forecaster's own chance of this, stated with the estimate: 35%); middle value at least 1.6-fold (0.22 log units) from the limit.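

Hydrogen on this aromatic carbon does not keep the measurable values seen with the two sulfonyl-bearing groups, giving an at least 2.1-fold higher number from compound 3 to compound 4 (0.33 log units; beyond the scatter) and an at least 2.4-fold higher number from compound 2 to compound 4 (0.38 log units; beyond the scatter). A substituent of that kind therefore matters here, which compounds 2 and 3 alone, with their level values, could not show. Compound 4 ends at a limit, not a number, as does compound 1, so the step between them cannot be read: the limit of > 100000 nM in this assay, at which 2 of the 4 values shown sit.

From the compounds shown here alone, whether a simple amine or a carboxylic acid on this carbon would restore a measurable value remains open. Also open, going by these compounds, is which part of the (((4-methylphenyl)sulfonyl)amino)methyl group carries the step.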